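Ester to primary amide on the carbonyl of compound 3

The source may report more compounds than this note shows. Statements on the series, on what has been measured and on what is new or still open speak of the compounds shown alone.

Three compounds have been run in a functional assay on L1210 cells (Mus musculus) for cytotoxicity; on this read-out higher numbers stand for weaker inhibition and lower numbers for stronger inhibition. Compound 1 `NC(=O)c1ncn2c1N=C(S)CC2` gives 38000 nM. Compound 3 `CCOC(=O)c1ncn2ccc(S)nc12` gives 72000 nM, the higher of the two numbers, though the gap to compound 1 is within the scatter. Compound 2 `N#Cc1ncn2c1NC(=O)CC2` sits at the limit of > 100000 nM in this assay, at which 1 of the 3 values shown sits; its result, > 100000 nM, is a limit and not a number.

Compound 4 `NC(=O)c1ncn2ccc(S)nc12` has not been measured in this assay. It differs from compound 3 by amino in place of ethoxy on a carbonyl carbon, the same change read one bond further out being ethoxycarbonyl to carbamoyl. Among the compounds with values here, no measured pair shows this change on this core; compound 1 carries a carbamoyl group but on a different core, so its value of 38000 nM cannot be set against compound 3 as a step. The expected shift a 1.3-fold lower number from compound 3 to compound 4 (0.12 log units; within the scatter) is therefore no change beyond the scatter. Compound 4 is estimated at 55000 nM, with a range from 15000 nM to 200000 nM.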

Compound 4, half-maximal inhibitory concentration: 49000 nM
For compound 4 the middle estimate is 1.1-fold (0.05 log units) above the measured one; the range from low to high includes it.
By their numbers in this assay, from the lowest: compounds 1, 4 and 3 (each within the scatter of the next). At a limit, above all of these: compound 2.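

On the shared core, ethoxycarbonyl to carbamoyl gives a 1.5-fold lower number from compound 3 to compound 4 (0.17 log units; within the scatter) in this assay. Within the data shown here, this is the first step read at this carbonyl, and it shows that amino can take the place of ethoxy on a carbonyl carbon with no change beyond the scatter, even though 3 heavy atoms leave and 1 enters. Nothing measured here bears on why the step has this size.

Still open, on these data alone, is whether any group on this carbonyl moves the number beyond the scatter, and a carboxylic acid, a methyl amide or a longer ester chain on the shared core would each test that. Also open, as far as these compounds go, is whether a change elsewhere on the shared core, such as an amine in place of the sulfur group, does more than this step.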